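Heteroaryl exchange on the shared core: expected half-life

This account rests on a few compounds, and the source may have more. Where it says the series, first, only, none or still open, it means among the compounds named here.

For the measured compounds named here, compound 2 `Cn1c(-c2ccncc2)c(C2CCCC2)c2ccc(C(=O)NC3(C(=O)Nc4ccc(/C=C/C(=O)O)cc4)CCC3)cc21` gives 1.87 h in an in vitro ADME assay on microsomes from liver (Homo sapiens) for metabolic stability (on this read-out lower numbers stand for a shorter-lived compound and higher numbers for a longer-lived compound), one of only two numbers so far; compound 1 `COc1ccc(-c2c(C3CCCC3)c3ccc(C(=O)NC4(C(=O)Nc5ccc(/C=C/C(=O)O)cc5)CCC4)cc3n2C)cn1` gives 1.58 h, and the two lie within the scatter of each other, as a 1.2-fold higher number from compound 1 to compound 2 (0.07 log units; within the scatter) shows. Compound 3 `Cn1c(-c2cnccn2)c(C2CCCC2)c2ccc(C(=O)NC3(C(=O)Nc4ccc(/C=C/C(=O)O)cc4)CCC3)cc21` carries the change (pyrazin-2-yl in place of pyridin-4-yl on an aromatic carbon). Going by the values given here, the one measured step that bears on this is a 1.2-fold higher number from compound 1 to compound 2 (0.07 log units; within the scatter), a heteroaryl exchange at the same carbon that stayed within the scatter. For compound 3 a step within the scatter is therefore expected, a 1.1-fold lower number from compound 2 to compound 3 (0.04 log units; within the scatter), with no clear direction. Compound 3 is estimated at 1.7 h, in a range of 0.9 h to 3.4 h.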

Compound 3, half-life: 1.6 h
For compound 3 the middle estimate is 1.1-fold (0.03 log units) above the measured one, within the range that was stated.
By their numbers in this assay, from the lowest: compounds 1, 3 and 2 (each within the scatter of the next).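

In this assay, a second ring nitrogen on the six-membered ring at this carbon, with pyrazin-2-yl in place of pyridin-4-yl, gives a 1.2-fold lower number from compound 2 to compound 3 (0.07 log units; within the scatter) and so does not move the half-life beyond the scatter. Pyrazin-2-yl in place of 6-methoxypyridin-3-yl gives a 1.0-fold higher number from compound 1 to compound 3 (0.01 log units; within the scatter), so all three heteroaryl groups in compound 1, compound 2 and compound 3 now lie within the scatter of one another.

From the compounds shown here alone, whether this holds for a plain phenyl ring or a saturated ring such as piperidine at the same carbon stays open. Nothing available gives a cause for these half-lives.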